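Swapping 4-methylphenyl for naphthalen-2-yl on compound 2

The source may report more compounds than this note shows. Statements on the series, on what has been measured and on what is new or still open speak of the compounds shown alone.

Three related compounds have been measured in an ADME assay on NIH3T3 cells (Homo sapiens) for cytotoxicity, read by sulforhodamine B assay, with a stated time of 48 h; a higher number here means a weaker inhibitor, a lower number a stronger inhibitor. Compound 2 `CC(=O)OC[C@H]1O[C@@H](n2cc(CN3C(=O)/C(=C/c4ccc(C)cc4)c4ccccc43)nn2)[C@H](OC(C)=O)[C@@H](OC(C)=O)[C@@H]1OC(C)=O` gives 73300 nM, the highest of the three numbers. Compound 1 `CC(=O)OC[C@H]1O[C@@H](n2cc(CN3C(=O)/C(=C\c4ccccc4)c4ccccc43)nn2)[C@H](OC(C)=O)[C@@H](OC(C)=O)[C@@H]1OC(C)=O` gives 22800 nM, and compound 3 `CC(=O)OC[C@H]1O[C@@H](n2cc(CN3C(=O)/C(=C\c4ccc(C)cc4)c4ccccc43)nn2)[C@H](OC(C)=O)[C@@H](OC(C)=O)[C@@H]1OC(C)=O` gives 9000 nM.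

Compound 4 `CC(=O)OC[C@H]1O[C@@H](n2cc(CN3C(=O)/C(=C/c4ccc5ccccc5c4)c4ccccc43)nn2)[C@H](OC(C)=O)[C@@H](OC(C)=O)[C@@H]1OC(C)=O` has naphthalen-2-yl in place of 4-methylphenyl on a double-bonded chain carbon bound to a double-bonded ring carbon. For the measured compounds named here, two measured steps bear on this change. The larger one, an 8.1-fold lower number from compound 2 to compound 3 (0.91 log units; beyond the scatter), comes down to the fact that compounds 2 and 3 differ only in the configuration as drawn. Compound 4 keeps the double bond drawn as in compound 2, so that step should not apply here. The closer guide is a 2.5-fold lower number from compound 1 to compound 3 (0.40 log units; beyond the scatter), a modest drop in this assay for methyl in place of hydrogen on an aromatic carbon, although it was measured with the double bond drawn the other way. This makes it only a loose guide to a change of aromatic group.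

The expected change is a modest one toward a lower number, a 1.8-fold lower number from compound 2 to compound 4 (0.26 log units; within the scatter). For compound 4 the estimated value is 40000 nM, with an expected range of 12000 nM to 110000 nM.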

Compound 4, half-maximal inhibitory concentration: 28400 nM
For compound 4 the middle estimate is 1.4-fold (0.15 log units) above the measured one; low and high end bracket the measured number.
By their numbers in this assay, from the lowest: compound 3; then compounds 1 and 4 (each within the scatter of the next); then compound 2.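

In this assay, a 2.6-fold lower number from compound 2 to compound 4 (0.41 log units; beyond the scatter) shows that the aromatic group at this position can change the number while the double bond stays drawn as in compound 2. The earlier compounds shown here showed an aromatic change only with the double bond drawn the other way, and that change was only methyl in place of hydrogen. Here, a second aromatic ring in naphthalen-2-yl comes with a lower number rather than a higher one, yet an 8.1-fold lower number from compound 2 to compound 3 (0.91 log units; beyond the scatter) remains the larger step, and the source of that step is clear: the fact that compounds 2 and 3 differ only in the configuration as drawn

From the compounds shown here alone, it remains open how naphthalen-2-yl behaves with the double bond drawn as in compound 3, and whether the gain from that drawing would carry over. Also open, going by these compounds, is what a pyridine ring, or an amine or carboxylic acid in place of the methyl of 4-methylphenyl, would do here.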